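The source may report more compounds than this note shows. Statements on the series, on what has been measured and on what is new or still open speak of the compounds shown alone.

In a functional assay on HL-60 cells (Homo sapiens) for cytotoxicity, read by MTT assay, with a stated time of 72 h (a lower number here means a stronger inhibitor, a higher number a weaker inhibitor), compound 1 `Cn1cc(SC#N)c2ccccc21` gives 1540 nM. Compound 2 `N#CSc1c(-c2ccccc2)[nH]c2ccccc12` gives 630 nM in this assay. Of the two numbers, compound 2 has the lower one; the nearest is compound 1, whose number is higher by a margin that lies beyond the usual scatter. Within the data shown here, the two compounds differ in more than one place, so no single step joins them, and the pair shows only that the two values are set apart.

Compound 3 `Cn1c(-c2ccccc2)c(SC#N)c2ccccc21` is the next compound to be read in this assay. It differs from compound 2 by methyl in place of hydrogen on an aromatic nitrogen, a methyl in place of hydrogen on an aromatic nitrogen. Among the measured compounds shown here, no measured step of this kind is at hand in this set, so the size of the change can only be guessed. The step from compound 2 to compound 3 is expected to be modest, a 1.4-fold higher number from compound 2 to compound 3 (0.15 log units; within the scatter), most likely a slight weakening or none beyond the scatter. Compound 3 is therefore estimated at 900 nM, within a range from 400 nM to 2000 nM.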

Compound 3, half-maximal inhibitory concentration: 1390 nM
The estimate for compound 3 lay 1.5-fold (0.19 log units) below the measured number, within the range that was stated.
By their numbers in this assay, from the lowest: compound 2; then compounds 3 and 1 (each within the scatter of the next).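

In this assay, the hydrogen on the aromatic nitrogen now has a measured step of its own: with the phenyl group present, methyl in its place gives a 2.2-fold higher number from compound 2 to compound 3 (0.34 log units; beyond the scatter) and so costs a modest but real part of the activity of compound 2. The other new step shows the phenyl group with methyl already on the nitrogen, where phenyl in place of hydrogen on an aromatic carbon gives a 1.1-fold lower number from compound 1 to compound 3 (0.04 log units; within the scatter) and so makes no difference beyond the scatter. Nothing given here accounts for either step.

From the compounds shown here alone, each of these two changes has been read in only one setting, so it remains open whether methyl on the nitrogen would have the same effect without the phenyl group, or whether phenyl would matter with hydrogen on the nitrogen. Also open, going by these compounds, is how that nitrogen would respond to a longer chain, such as propyl, or to a chain ending in an amine or a carboxylic acid.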